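A few compounds are considered here, and "the series" means these few. Any claim that something is new, unique, unknown or untested is made for them only; others in the source may bear on it.

Compound 3 `CCCCc1ccc(CNS(C)(=O)=O)c(=O)n1Cc1ccc(-c2ccccc2-c2nn[nH]n2)cc1` gives 2 nM in a functional assay (aorta) for antagonist activity, with Oryctolagus cuniculus as the target (a higher number here means a weaker inhibitor, a lower number a stronger inhibitor), the second highest of the three numbers; compound 2 `CCCCc1ccc(CN(Cc2ccccc2)C(C)=O)c(=O)n1Cc1ccc(-c2ccccc2-c2nn[nH]n2)cc1` gives 1 nM, within the scatter of it, while compound 1 `CCCCc1ccc(CNC(=O)Nc2ccccc2)c(=O)n1Cc1ccc(-c2ccccc2-c2nn[nH]n2)cc1` gives 30 nM, the step from compound 1 to compound 3 being a 15-fold lower number from compound 1 to compound 3 (1.18 log units; beyond the scatter). Compound 4 `CCCCc1ccc(CN(CC)S(C)(=O)=O)c(=O)n1Cc1ccc(-c2ccccc2-c2nn[nH]n2)cc1` differs from compound 3 by ethyl in place of hydrogen on a sulfonamide nitrogen. Within the data shown here, no measured step alters a sulfonamide nitrogen alone. The nearest guides are a 30-fold lower number from compound 1 to compound 2 (1.48 log units; beyond the scatter), where acetyl(benzyl)amino replaces (phenylcarbamoyl)amino, and a 2.0-fold higher number from compound 2 to compound 3 (0.30 log units; within the scatter), where acetyl(benzyl)amino and methanesulfonamido lie within scatter of each other. On that basis no step beyond the scatter is expected for compound 4, a 1.3-fold higher number from compound 3 to compound 4 (0.10 log units; within the scatter). Compound 4 is estimated at 2.5 nM, in a range from 0.8 nM to 8 nM.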

Compound 4, half-maximal inhibitory concentration: 2 nM
Estimate against measurement, compound 4: 1.3-fold (0.10 log units) above; measured number inside the range.
By their numbers in this assay, from the lowest: compounds 2, 3 and 4 (each within the scatter of the next); then compound 1.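

In this assay, among these compounds, this is the first step to alter the sulfonamide nitrogen alone, and ethyl in place of hydrogen there leaves the number within the scatter (no change at the digits printed from compound 3 to compound 4 (within the scatter)). The ethyl(methylsulfonyl)amino group also sits within the scatter of the acetyl(benzyl)amino group (a 2.0-fold higher number from compound 2 to compound 4 (0.30 log units; within the scatter)), and it keeps the large separation from the (phenylcarbamoyl)amino group (a 15-fold lower number from compound 1 to compound 4 (1.18 log units; beyond the scatter)). No evidence here accounts for this result. As far as these compounds go, whether a longer chain such as butyl, or a carboxylic acid, on this nitrogen would stay within the scatter remains open.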